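Amide Substituent and a Phenol in a Cytotoxicity Series

The compounds below may be only part of what the source reports. "The series", "measured", "known", "first", "only" and "open" are said of these compounds alone.

Compound 1 `COc1ccc2c(=O)c(/C=C/C(=O)Nc3ccccc3)coc2c1` gives 523000 nM in an ADME assay on HepG2 2.2.15 cells (Homo sapiens) for cytotoxicity, read by MTT assay, with stated times of 48 h and 9 days; a lower number here means that less compound is tolerated, a higher number that more compound is tolerated.
Compound 2 `COc1ccc2c(=O)c(/C=C/C(=O)NCc3ccc(C)cc3)coc2c1` gives 257000 nM in this assay.
Compound 3 `Cc1ccc(CNC(=O)/C=C/c2coc3cc(O)ccc3c2=O)cc1` gives 501000 nM in this assay.

These three compounds share one core and differ at two places. Going from compound 2 to compound 1, the change is phenyl in place of 4-methylbenzyl on an amide-type nitrogen, and it brought a 2.0-fold higher number from compound 2 to compound 1 (0.31 log units; beyond the scatter). Going from compound 2 to compound 3, the two cores differ by hydrogen in place of methyl on an oxygen on an aromatic ring, which brought a 1.9-fold higher number from compound 2 to compound 3 (0.29 log units; within the scatter). The values of compound 1 and compound 3 lie within the scatter of each other.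

Compound 4 `O=C(/C=C/c1coc2cc(O)ccc2c1=O)Nc1ccccc1` has not yet been measured in this assay. It differs from compound 3 by phenyl in place of 4-methylbenzyl on an amide-type nitrogen, the same change, at the same place, as that from compound 2 to compound 1. Because that earlier step was a 2.0-fold higher number from compound 2 to compound 1 (0.31 log units; beyond the scatter), a step of similar size is expected here, namely a 2.0-fold higher number from compound 3 to compound 4 (0.30 log units; within the scatter). Compound 4 is therefore estimated at 1000000 nM, with a likely range from 500000 nM to 2000000 nM.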

Compound 4, half-maximal cytotoxic concentration: 821000 nM
For compound 4 the middle estimate is 1.2-fold (0.09 log units) above the measured one; the range from low to high includes it.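

Putting phenyl in place of 4-methylbenzyl on the amide-type nitrogen of compound 3 gives a 1.6-fold higher number from compound 3 to compound 4 (0.21 log units; within the scatter) in this assay, and this agrees with the same change on the other core: the same change on two cores in this assay, a 2.0-fold higher number (0.31 log units; beyond the scatter) from compound 2 to compound 1 and a 1.6-fold higher number (0.21 log units; within the scatter) from compound 3 to compound 4, 1.2-fold (0.09 log units) apart, within the scatter of two such steps. The second change, hydrogen in place of methyl on an oxygen on an aromatic ring, gives a 1.6-fold higher number from compound 1 to compound 4 (0.20 log units; within the scatter), and it also agrees with its earlier step: the same change on two cores in this assay, a 1.9-fold higher number (0.29 log units; within the scatter) from compound 2 to compound 3 and a 1.6-fold higher number (0.20 log units; within the scatter) from compound 1 to compound 4, 1.2-fold (0.09 log units) apart, within the scatter of two such steps. Each change therefore carried over between these two cores with a similar size, but both new steps lie within the usual scatter, and a single pair of cores for each change cannot establish a general rule for the series.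

The compounds shown leave open whether this agreement would hold for other groups on the amide-type nitrogen, such as a chain ending in an amine or a carboxylic acid, or for a longer chain in place of methyl on the oxygen. They also leave open whether either change would carry over to a third core.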